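Bromo for Aryl: Cytotoxicity Series Notes

This account rests on a few compounds, and the source may have more. Where it says the series, first, only, none or still open, it means among the compounds named here.

Compound 1 `CCOC(=O)CCCCCOc1cccc(CN(C(=O)c2ccc(-c3cccc(NC(C)=O)c3)cc2)C(C)C)c1`, cytotoxicity > 26000 nM, a limit.
Compound 2 `CCOC(=O)CCCCCOc1cccc(CN(C(=O)c2ccc(-c3cc(OC)ccc3F)cc2)C(C)C)c1`, cytotoxicity > 26000 nM, a limit.

In an ADME assay on BJ cells (Homo sapiens) for cytotoxicity, read by CellTiter-Glo and resazurin assay, with a stated time of 72 h (a higher number here means that more compound is needed for the effect, a lower number that less compound is needed), compound 2 gives > 26000 nM, which is a limit of the assay and not a number. Both measured values rest at the limit of > 26000 nM in this assay, at which 2 of the 2 values shown sit, so the step that the two limits leave unreadable from compound 1 to compound 2 cannot be sized. Compound 3 `CCOC(=O)CCCCCOc1cccc(CN(C(=O)c2ccc(Br)cc2)C(C)C)c1` carries bromo in place of 2-fluoro-5-methoxyphenyl on an aromatic carbon. Within the data shown here, the only measured step is unreadable, so no direction beyond the scatter can be drawn for this change. Compound 3 is expected at 30000 nM, between 15000 nM and 80000 nM. The step expected is a step that the limit leaves unreadable from compound 2 to compound 3.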

Compound 3, half-maximal effective concentration: > 26000 nM
Compound 3: a limit, no number; the forecaster's own chance of this, stated with the estimate: 75%; the middle value lies beyond the limit too.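

No step among compound 1, compound 2 and compound 3 can be read in this assay, as each value is a limit: the limit of > 26000 nM in this assay, at which 3 of the 3 values shown sit.

Still open is the concentration at which any of these compounds reaches the effect, and whether the exchanged groups differ at all.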